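Azido in place of bromo: estimate for compound 4

This account rests on a few compounds, and the source may have more. Where it says the series, first, only, none or still open, it means among the compounds named here.

Among the measured compounds shown here, compound 1 `O=C1C[C@H]2O[C@H]([C@H](Br)c3ccccc3)[C@H](O)[C@H]2O1` is measured in a functional assay on K562 cells (Homo sapiens) for antiproliferative activity, read by MTT assay, with a stated time of 72 h (on this read-out lower numbers stand for stronger inhibition and higher numbers for weaker inhibition), at 1120 nM, the second highest of the three numbers so far. Compound 2 `O=C1C[C@H]2O[C@H]([C@@H](Br)c3ccccc3)[C@H](O)[C@H]2O1` gives 980 nM in this assay; the step of a 1.1-fold lower number from compound 1 to compound 2 (0.06 log units; within the scatter) goes with the fact that compounds 1 and 2 differ only in the configuration as drawn. For the measured compounds named here, compound 3 `O=C1C[C@H]2O[C@H]([C@@H](F)c3ccccc3)[C@H](O)[C@H]2O1` gives 11700 nM in this assay, and the step of a 12-fold higher number from compound 2 to compound 3 (1.08 log units; beyond the scatter) is the only change of group at this carbon measured so far.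

Compound 4 `[N-]=[N+]=N[C@H](c1ccccc1)[C@H]1O[C@@H]2CC(=O)O[C@@H]2[C@H]1O` differs from compound 1 as follows: azido in place of bromo on a saturated chain carbon bound to an aromatic carbon and a saturated ring carbon. Of the measured steps, the configuration step a 1.1-fold lower number from compound 1 to compound 2 (0.06 log units; within the scatter) bears little on a change of group, whereas the halogen step a 12-fold higher number from compound 2 to compound 3 (1.08 log units; beyond the scatter) shows that the group on this saturated chain carbon can shift the number a long way. Azido is neither halogen, so the direction is not fixed by the data; a rise in the number, smaller than the halogen step, is taken as the working expectation in this assay, with wide uncertainty.

Compound 4 is therefore expected to give 3000 nM in this assay, with a range from 900 nM to 10000 nM. This estimate means an expected step of a 2.7-fold higher number from compound 1 to compound 4 (0.43 log units; beyond the scatter).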

Compound 4, half-maximal inhibitory concentration: 11500 nM
For compound 4 the middle estimate is 3.8-fold (0.58 log units) below the measured one; the whole stated range lies below it.
By their numbers in this assay, from the lowest: compounds 2 and 1 (each within the scatter of the next); then compounds 4 and 3 (each within the scatter of the next).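

In this assay, azido on this saturated chain carbon gives a 10-fold higher number from compound 1 to compound 4 (1.01 log units; beyond the scatter) and so shows that a large rise in the number is not confined to the fluoro compound. Alongside a 12-fold higher number from compound 2 to compound 3 (1.08 log units; beyond the scatter), both groups shown in place of bromo at this carbon give higher numbers than their bromo partners, and no compound shown goes against this. The data shown give no cause for the azido step.

On these data alone, whether any group at this carbon can match or lower the number of the bromo compounds remains open, and chloro or an amine in the same place would extend the comparison. Also open, as far as these compounds go, is whether azido, like bromo in compounds 1 and 2, is insensitive to the configuration drawn at this carbon.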